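Aryl exchange in the series: compound 2 to compound 3

This account rests on a few compounds, and the source may have more. Where it says the series, first, only, none or still open, it means among the compounds named here.

Of the compounds shown here, two have been measured in a functional assay on HEK293 cells with D(4) dopamine receptor (Homo sapiens) as the target, read by FLIPR; a lower number here means that less compound is needed, a higher number that more compound is needed for the effect. Compound 1 `Cc1ccccc1/C(CCN1CCN(c2ccccn2)CC1)=N\O` gives 20.3 nM. Compound 2 `O/N=C(\CCN1CCN(c2ccccn2)CC1)c1cccc(F)c1` gives 17.1 nM, the lower of the two numbers; its nearest neighbour is compound 1, and the gap between them lies within the scatter, so no order between the two can be stated.

Compound 3 `Cc1cc(C)cc(/C(CCN2CCN(c3ccccn3)CC2)=N/O)c1` has not been measured. It differs from compound 2 in one place: 3,5-dimethylphenyl in place of 3-fluorophenyl on a carbon with a double bond to nitrogen. Within the data shown here, no step between two measured compounds that differ in a single place is available, and compound 1 and compound 2, which carry different aryl groups at the same carbon, show two values within the scatter of each other. On that basis the step of a 1.5-fold higher number from compound 2 to compound 3 (0.16 log units; within the scatter) is expected to stay within the scatter, with no direction preferred. In this assay compound 3 is therefore estimated at 25 nM, with a range from 8 nM to 80 nM to allow for the wider uncertainty of an untested group.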

Compound 3, half-maximal effective concentration: 45.8 nM
Estimate against measurement, compound 3: 1.8-fold (0.26 log units) below; the measured number falls inside the stated range.
By their numbers in this assay, from the lowest: compounds 2 and 1 (each within the scatter of the next); then compound 3.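

In this assay, among these compounds, 3,5-dimethylphenyl in place of 3-fluorophenyl on the carbon with a double bond to nitrogen gives a 2.7-fold higher number from compound 2 to compound 3 (0.43 log units; beyond the scatter), the first step at this position that lies beyond the scatter, though it remains modest. Compound 1 and compound 2 alone could not show whether the number responds to the aryl group at this carbon at all; compound 3 shows that it does, with the rest of the structure of compound 2 kept. The leaving and entering groups have the same counts of hydrogen-bond donors and acceptors and the same net charge, and no measurement at hand bears on the reason for the step.

Among the compounds shown here, the single step does not separate the loss of fluorine from the gain of the methyl groups, and one exchange gives no trend across aryl groups. Also open, going by these compounds, is how the number would respond to a phenyl group without substituents, or to a methoxy group or a nitrile on the ring in place of the methyl groups.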